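Six-Membered Carbocycle Replaces the Bicyclic Amide Group

The source may report more compounds than this note shows. Statements on the series, on what has been measured and on what is new or still open speak of the compounds shown alone.

In an assay on HEK293 cells for positive allosteric modulation of metabotropic glutamate receptor 5 (Homo sapiens), read by FLIPR (on this read-out lower numbers stand for an effect already at smaller amounts and higher numbers for an effect only at larger amounts of compound), compound 3 `O=C([C@@H]1CC2CCC1C2)N1CC(c2nc(-c3cccc(Cl)c3)no2)C1` gives 98 nM, the lowest of the two numbers available. Compound 1 `O=C(C1CCC(F)(F)CC1)N1CC(c2nc(-c3cccc(Cl)c3)no2)C1` gives 180 nM, and the step of a 1.8-fold lower number from compound 1 to compound 3 (0.26 log units; within the scatter) stays within the scatter. Compound 2 `CC1CN(C(=O)N2CC(c3nc(-c4cccc(Cl)c4)no3)C2)CC(C)O1` reaches only a limit of this assay, > 10000 nM. That value is the limit of > 10000 nM in this assay, at which 1 of the 3 values shown sits.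

Compound 4 `CC1CCCC(C(=O)N2CC(c3nc(-c4cccc(Cl)c4)no3)C2)C1` changes compound 3 at the carbonyl carbon: a group of 7 heavy atoms (7 carbon; one six-membered non-aromatic ring of carbon only) in place of a group of 7 heavy atoms (7 carbon; 2 five-membered non-aromatic rings of carbon only), on a carbonyl carbon. Within the data shown here, two measured steps bear on this. The exchange of the 4,4-difluorocyclohexyl for the bicyclic group, a 1.8-fold lower number from compound 1 to compound 3 (0.26 log units; within the scatter), was within the scatter, so a six-membered carbon ring and the bicyclic group have so far given similar numbers. The large step of an at least 100-fold lower number from compound 2 to compound 3 (2.00 log units; beyond the scatter) concerned a ring with two hetero atoms, which compound 4 does not carry. The 3-methylcyclohexyl group, all carbon like both the bicyclic group and the ring of compound 1, is therefore expected to give a step of about a 1.5-fold higher number from compound 3 to compound 4 (0.18 log units; within the scatter), none beyond the scatter. Compound 4 is estimated at 150 nM, with a range from 60 nM to 450 nM.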

Compound 4, half-maximal effective concentration: 410 nM
For compound 4 the middle estimate is 2.7-fold (0.44 log units) below the measured one; measured number inside the range.
By their numbers in this assay, from the lowest: compounds 3 and 1 (each within the scatter of the next); then compound 4. At a limit, above all of these: compound 2.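

In this assay, carbon-only groups on the carbonyl carbon do not all give similar numbers: the 3-methylcyclohexyl group gives a 4.2-fold higher number from compound 3 to compound 4 (0.62 log units; beyond the scatter), and in place of 4,4-difluorocyclohexyl it gives a 2.3-fold higher number from compound 1 to compound 4 (0.36 log units; beyond the scatter). Compound 3 and compound 1 remain within the scatter of each other, while compound 4 stands apart from both, so a ring of carbon alone does not settle the number at this position. The 3-methylcyclohexyl group still differs widely from 2,6-dimethylmorpholin-4-yl, with an at least 24-fold lower number from compound 2 to compound 4 (1.38 log units; beyond the scatter), and the size of that step is bounded by a limit for compound 2: the limit of > 10000 nM in this assay, at which 1 of the 4 values shown sits.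

Open, on these data alone, is how an unsubstituted cyclohexyl group on the carbonyl carbon would compare with the 3-methylcyclohexyl group of compound 4, and so what the methyl group itself contributes. Also open, as far as these compounds go, is how a piperidin-1-yl group would compare with the 2,6-dimethylmorpholin-4-yl group of compound 2.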